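Compound 4 in a flat cytotoxicity series

The source may report more compounds than this note shows. Statements on the series, on what has been measured and on what is new or still open speak of the compounds shown alone.

Measured in an ADME assay on L6 cells (Rattus norvegicus) for cytotoxicity, read by resazurin assay, with a stated time of 72 h; a lower number here means a stronger inhibitor, a higher number a weaker inhibitor:
compound 1 `CN(C)C12CC(c3ccccc3)C(CN(C(=O)CN3CCCC3)C1)C(c1ccccc1)C2`: 12600 nM
compound 2 `CN1CCN(CCC(=O)N2CC3C(c4ccccc4)CC(N(C)C)(CC3c3ccccc3)C2)CC1`: 13000 nM
compound 3 `CN(C)C12CC(c3ccccc3)C(CN(C(=O)CCN3CCCC3)C1)C(c1ccccc1)C2`: 11700 nM

Compound 3 stands level with the other two compounds, since neither of its steps leaves the scatter: a 1.1-fold lower number from compound 1 to compound 3 (0.03 log units; within the scatter) and a 1.1-fold lower number from compound 2 to compound 3 (0.05 log units; within the scatter). The third step, a 1.0-fold higher number from compound 1 to compound 2 (0.01 log units; within the scatter), also stays within it. Compound 4 `CN(C)C12CC(c3ccccc3)C(CN(C(=O)CCN3CCCCC3)C1)C(c1ccccc1)C2` differs from compound 3 at one place: piperidin-1-yl in place of pyrrolidin-1-yl on a saturated chain carbon, two bonds along the chain from a carbonyl carbon. The step from compound 2 bears most closely, as it changes the ring at this same carbon, and it was within the scatter. No step beyond the scatter is therefore expected in this assay. The expected step is a 1.1-fold lower number from compound 3 to compound 4 (0.03 log units; within the scatter). Compound 4 is estimated at 11000 nM, with an expected range from 6500 nM to 18000 nM.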

Compound 4, half-maximal inhibitory concentration: 12400 nM
The estimate for compound 4 lay 1.1-fold (0.05 log units) below the measured number; low and high end bracket the measured number.
By their numbers in this assay, from the lowest: compounds 3, 4, 1 and 2 (each within the scatter of the next).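

In this assay, piperidin-1-yl joins pyrrolidin-1-yl and 4-methylpiperazin-1-yl as a ring that leaves the number level at this saturated chain carbon, with a 1.1-fold higher number from compound 3 to compound 4 (0.03 log units; within the scatter) and a 1.0-fold lower number from compound 2 to compound 4 (0.02 log units; within the scatter) as the two steps. Changing ring and chain together, with (piperidin-1-yl)methyl in place of pyrrolidin-1-yl, also stays within the scatter, as a 1.0-fold lower number from compound 1 to compound 4 (0.01 log units; within the scatter) shows. No available evidence accounts for this flatness. The compounds shown leave open whether an open-chain dimethylamino group, a carboxylic acid or a longer chain at this place would move the number beyond the scatter.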